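This account rests on a few compounds, and the source may have more. Where it says the series, first, only, none or still open, it means among the compounds named here.

Compound 1, with the structure `COc1ccc(Oc2ccc(C(C)C)cc2-c2ccsc2S(=O)(=O)NCCNC(=O)Nc2cc(Cl)cc(Cl)c2)cc1OC`, carries a 3,4-dimethoxyphenyl group on an oxygen on an aromatic ring, and in a functional assay on RS4-11 cells (Homo sapiens) for inhibition, read by CCK-8 assay, with a stated time of 48 h (a higher number here means a weaker inhibitor, a lower number a stronger inhibitor), compound 1 gives 9000 nM. Compound 2, `CC(C)c1ccc(Oc2ccc(O)c(O)c2)c(-c2ccsc2S(=O)(=O)NCCNC(=O)Nc2cc(Cl)cc(Cl)c2)c1`, differs from it by the change (3,4-dihydroxyphenyl in place of 3,4-dimethoxyphenyl on an oxygen on an aromatic ring), and in this assay compound 2 gives 6400 nM. That change brought a 1.4-fold lower number from compound 1 to compound 2 (0.15 log units; within the scatter), so the two values cannot be told apart.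

Compound 3 has the structure `COc1ccc(Oc2ccccc2-c2ccsc2S(=O)(=O)N2CCN(C(=S)Nc3ccc(Cl)cc3)CC2)cc1OC`; its core differs from that of compound 1 in more than one place, and the difference between the two cores is not broken down here. In this assay compound 3 reaches only the limit of the measurement, > 50000 nM, which is the limit of > 50000 nM in this assay, at which 1 of the 3 values shown sits.

Compound 4, `O=S(=O)(c1sccc1-c1ccccc1Oc1ccc(O)c(O)c1)N1CCN(C(=S)Nc2ccc(Cl)cc2)CC1`, is not yet measured. It stands to compound 3 as compound 2 stands to compound 1: the same change, (3,4-dihydroxyphenyl in place of 3,4-dimethoxyphenyl on an oxygen on an aromatic ring), at the same place. Since the first instance gave a 1.4-fold lower number from compound 1 to compound 2 (0.15 log units; within the scatter), the step is expected to be a step that the limit leaves unreadable from compound 3 to compound 4, and because compound 3 sits at > 50000 nM, compound 4 is expected to give about 70000 nM, most likely again as a limit rather than a number.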

Compound 4, half-maximal inhibitory concentration: 7500 nM
Compound 4: the middle estimate sits 9.3-fold (0.97 log units) above what was measured, and the stated range ends above it.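

In this assay the same replacement of 3,4-dimethoxyphenyl by 3,4-dihydroxyphenyl gave an at least 6.6-fold lower number from compound 3 to compound 4 (0.82 log units; beyond the scatter), and the size of the step did not carry over from the core of compound 1 to the core of compound 3: the same change on two cores in this assay, a 1.4-fold lower number (0.15 log units; within the scatter) from compound 1 to compound 2 and an at least 6.6-fold lower number (0.82 log units; beyond the scatter) from compound 3 to compound 4, at least 4.7-fold (0.67 log units) apart, beyond the scatter of two such steps

Compound 3 gives > 50000 nM, which is a limit of the assay and not a number: the limit of > 50000 nM in this assay, at which 1 of the 4 values shown sits.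

The two steps show that this change does not have one fixed size in this series, but they do not show which of the several differences between the two cores goes with the gap, nor how the change would read on any further core.

Still open, going by these compounds, is how a phenyl carrying a single hydroxyl group, or one carrying a carboxylic acid, would read in place of 3,4-dihydroxyphenyl on either core. Also open, on these data alone, is whether the gap would remain on a core that differs from the core of compound 3 in only one place.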